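Replacing 4-chlorophenyl with 3-nitrophenyl: working notes

This account rests on a few compounds, and the source may have more. Where it says the series, first, only, none or still open, it means among the compounds named here.

Measured in a functional assay on HepG2 cells (Homo sapiens) for cytotoxicity, read by MTT assay, with a stated time of 24 h; a higher number here means a weaker inhibitor, a lower number a stronger inhibitor
compound 1 `CN1C/C(=C\c2ccc(C(C)(C)C)cc2)C(=O)/C(=C/c2ccccc2F)C1` gives 9120 nM
compound 2 `CN1C/C(=C\c2ccc(C(F)(F)F)cc2)C(=O)/C(=C/c2ccccc2F)C1` gives 4140 nM
compound 3 `COc1cc(/C=C2\CN(C)C/C(=C\c3ccc(Cl)cc3)C2=O)cc(OC)c1` gives 5950 nM

Compound 3 lies within the scatter of both compound 1 and compound 2, even though those two are separated by a step beyond the scatter. Still unmeasured is compound 4 `COc1cc(/C=C2\CN(C)C/C(=C\c3cccc([N+](=O)[O-])c3)C2=O)cc(OC)c1` with 3-nitrophenyl in place of 4-chlorophenyl on a double-bonded chain carbon bound to a double-bonded ring carbon. The counted difference is 3-nitrophenyl in place of 4-chlorophenyl on a double-bonded chain carbon bound to a double-bonded ring carbon and nothing else changes.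

Within the data shown here, only one measured step bears on this, and only loosely: a 2.2-fold lower number from compound 1 to compound 2 (0.34 log units; beyond the scatter) with trifluoromethyl in place of tert-butyl on an aromatic carbon. That step was modest, and it involves neither group exchanged here. Among the measured compounds shown here, no measured compound carries 3-nitrophenyl, so the data fix no direction. A step of similar modest size is the most that can be expected in this assay and none beyond the scatter is the likeliest outcome. The expectation therefore starts from compound 3 at 5950 nM with only a slight allowance for change. The estimated step is a 1.2-fold lower number from compound 3 to compound 4 (0.08 log units; within the scatter) with a wide margin on either side. The estimate for compound 4 is 5000 nM with an expected range from 2000 nM to 11000 nM for the measurement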

Compound 4, half-maximal inhibitory concentration: 1840 nM
For compound 4 the middle estimate is 2.7-fold (0.43 log units) above the measured one; measured number outside the range, below it.
By their numbers in this assay, from the lowest: compound 4; then compounds 2, 3 and 1 (each within the scatter of the next, the first and the last beyond it).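

In this assay, 3-nitrophenyl in place of 4-chlorophenyl on a double-bonded chain carbon bound to a double-bonded ring carbon gives a 3.2-fold lower number from compound 3 to compound 4 (0.51 log units; beyond the scatter), so the number in this series does respond to the aryl group at this place. The earlier step, a 2.2-fold lower number from compound 1 to compound 2 (0.34 log units; beyond the scatter), concerned trifluoromethyl in place of tert-butyl on an aromatic carbon and gave no reading on this exchange, in which 2 hydrogen-bond acceptors enter where the leaving group has none. Nothing available accounts for the new step, and this one pair cannot separate the change of substituent from the change of where it sits on the phenyl ring.

From the compounds shown here alone, whether 3-chlorophenyl or 4-nitrophenyl would give a number closer to compound 3 or to compound 4 remains open, as does the outcome for an amine on the same phenyl ring. Going by these compounds, the step is also read only on the core of compound 3, so whether 3-nitrophenyl has a similar effect on the core of compound 1 is unknown.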